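Ethylsulfanyl thioester in place of an isopentyl ester

The source may hold more compounds than are shown below. What is called first, only, known or untested is meant among the compounds shown, and "the series" means these compounds.

Measured compounds:
Compound 1, `CC(/C=C/CC(C)CCCC(C)C)=C\C(=O)OC(C)C`, gives 7.15 in a physicochemical assay for lipophilicity; on this read-out lower numbers stand for lower lipophilicity and higher numbers for higher lipophilicity.
Compound 2, `COC(C)(C)CCCC(C)C/C=C/C(C)=C/C(=O)OCCC(C)C`, gives 7.03 in this assay.
Compound 3, `CCOC(=O)/C=C(C)/C=C/CC(C)CCC(SCC)C(C)C`, gives 6.9 in this assay.

All three measured compounds share a long branched chain carrying a conjugated diene ester and sit close together on this read-out. Compound 2 lies within the usual scatter of both compound 1 and compound 3, so no ordering among the three can be claimed; the numbers simply show three closely similar, strongly lipophilic compounds.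

Compound 4, `CCSC(=O)/C=C(C)/C=C/CC(C)CCCC(C)(C)OC`, has not yet been measured. Compared with compound 2 it differs in one place: ethylsulfanyl in place of isopentyloxy on a carbonyl carbon. The group that leaves carries five carbons and one oxygen; the group that enters carries two carbons and one sulfur. Among the compounds with values here, no pair of measured compounds shows this kind of exchange, so there is no measured step to lean on. Still, three carbon atoms fewer in the chain would ordinarily be expected to lower the partition coefficient by a clear margin, beyond the scatter, while the sulfur in place of oxygen is expected to take back only part of that loss.

On this basis compound 4 is expected to give about 6.1, within a range of 5.5 to 6.7. The estimated step from compound 2 to compound 4 is thus a number 0.93 log units lower from compound 2 to compound 4 (beyond the scatter), a decrease well beyond the scatter.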

Compound 4, partition coefficient: 6.78
Estimate against measurement, compound 4: 0.68 log units below; the whole stated range lies below it.
By their numbers in this assay, from the lowest: compounds 4, 3, 2 and 1 (each within the scatter of the next, the first and the last beyond it).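

This pair is the first shown that differs in one place, and in this assay the step for ethylsulfanyl in place of isopentyloxy on a carbonyl carbon reads a number 0.25 log units lower from compound 2 to compound 4 (within the scatter) and so gives no firm difference between the two compounds. At this position, then, a group of 6 heavy atoms can be exchanged for one of 3 heavy atoms, with sulfur taking the place of oxygen, and the result still stays within the usual spread of repeat measurements. Nothing shown gives a reason for this result.

The compounds shown leave open how much of this single step belongs to the shorter chain and how much to the sulfur, since both differ at once and no pair separates them. They also leave open whether this position would respond in the same way to a group of another kind on the carbonyl carbon, such as an amine forming an amide, a free carboxylic acid, or a longer sulfur-linked chain such as hexylsulfanyl.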